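The source may hold more compounds than are shown below. What is called first, only, known or untested is meant among the compounds shown, and "the series" means these compounds.

Measured so far in an assay on isolated protein for inhibition of serine/threonine-protein kinase MRCK alpha (Homo sapiens), read by luminescence, with a stated time of 75 min; on this read-out lower numbers stand for stronger inhibition and higher numbers for weaker inhibition:
compound 1 `COc1ccc2c(c1)C[C@H](C(=O)Nc1ccc(-c3cn[nH]c3)cc1O[C@H]1CCN(C)C1)CO2` — 294 nM
compound 2 `COc1ccc2c(c1)C[C@@H](C(=O)Nc1ccc(-c3cn[nH]c3)cc1O[C@H]1CCN(C)C1)CO2` — "not determined" (no result reported)

Going by the values given here, compound 1 carries the only number: in this assay compound 1 gives 294 nM. Compound 2 is its counterpart, and the fact that compounds 1 and 2 differ only in the configuration as drawn is the whole of what separates the two structures; as no value for compound 2 is reported, the pair yields no comparison.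

Compound 3 `COc1ccc2c(c1)C[C@H](C(=O)Nc1ccc(-c3cn[nH]c3)cc1OCCCO)CO2` is the next entry awaiting measurement in this assay. It differs from compound 1 by 3-hydroxypropyl in place of 1-methylpyrrolidin-3-yl on an oxygen on an aromatic ring. Among the compounds with values here, no measured step shows what a change at this position does, so the direction rests on the single anchor. The step from compound 1 to compound 3 is expected to run toward weaker inhibition, by a 2.7-fold higher number from compound 1 to compound 3 (0.43 log units; beyond the scatter). Compound 3 is therefore estimated at 800 nM, with a plausible range from 250 nM to 2500 nM.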

Compound 3, half-maximal inhibitory concentration: 74 nM
For compound 3 the middle estimate is 11-fold (1.03 log units) above the measured one; measured number below the stated range.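

In this assay, going by these compounds alone, 3-hydroxypropyl in place of 1-methylpyrrolidin-3-yl on an oxygen on an aromatic ring gives a 4.0-fold lower number from compound 1 to compound 3 (0.60 log units; beyond the scatter), the first measured evidence that the number responds to the group at this position. The entering group has no ring and no defined stereocentre, so, on this core, neither feature of 1-methylpyrrolidin-3-yl is required for the inhibition seen with compound 3. Nothing available on the series bears on why the number falls.

Still open, going by these compounds, is whether the terminal hydroxyl or the chain carries the change, which a 3-methoxypropyl group, a longer chain such as 4-hydroxybutyl, or an open-chain amine such as 3-(dimethylamino)propyl would help separate. The effect of configuration also remains unread, as the pair of compound 1 and compound 2 cannot be compared.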